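Swapping hydroxymethyl for hydrogen in compound 2

A few compounds are considered here, and "the series" means these few. Any claim that something is new, unique, unknown or untested is made for them only; others in the source may bear on it.

Values in an ADME assay on Huh-7 cells (Homo sapiens) for cytotoxicity, with a stated time of 72 h (a lower number here means that less compound is tolerated, a higher number that more compound is tolerated), for the measured compounds
- compound 1 (`COc1ccc(/C=C\c2cc(OC)c(OC)c(OC)c2)cc1NC(=O)[C@H](CO)NC(=O)[C@H](CCCNC(=N)N)NC(=O)[C@H](CCCCN)NC(=O)c1ccccc1`) gives 134 nM
- compound 2 (`COc1ccc(/C=C\c2cc(OC)c(OC)c(OC)c2)cc1NC(=O)[C@H](CO)NC(=O)[C@H](CCCNC(=N)N)NC(=O)[C@H](CCCNC(=N)N)NC(=O)c1ccccc1`) gives 23.1 nM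
- compound 3 (`COc1ccc(/C=C\c2cc(OC)c(OC)c(OC)c2)cc1NC(=O)CN`) gives 26.9 nM

Compound 2 (23.1 nM) and compound 3 (26.9 nM) lie within the scatter of each other and sit at the low end of the three numbers, while compound 1 stands apart (134 nM).

Compound 4 (`COc1ccc(/C=C\c2cc(OC)c(OC)c(OC)c2)cc1NC(=O)CNC(=O)[C@H](CCCNC(=N)N)NC(=O)[C@H](CCCNC(=N)N)NC(=O)c1ccccc1`) matches compound 2 except for one change (hydrogen in place of hydroxymethyl on a saturated chain carbon bound to an amide-type nitrogen and a carbonyl carbon). The hydroxymethyl leaves and a hydrogen enters in its place. Within the data shown here, only one measured step is available as a guide (a 5.8-fold lower number from compound 1 to compound 2 (0.76 log units; beyond the scatter)). That step is modest, but it swaps a different group and leaves the hydroxymethyl untouched, so it gives no direct size for this change. Compound 3 also lacks the hydroxymethyl, and its value (26.9 nM) lies within the scatter of the value of compound 2, although it differs from compound 2 in much else. One step and one loose comparison are thin evidence, so no step beyond the scatter is expected in this assay, and neither direction is favoured. The expected change is small (a 1.1-fold higher number from compound 2 to compound 4 (0.03 log units; within the scatter)). For compound 4 the estimated value is 25 nM with an expected range (11 nM to 60 nM).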

Compound 4, half-maximal cytotoxic concentration: 26.6 nM
For compound 4 the middle estimate is 1.1-fold (0.03 log units) below the measured one; measured number inside the range.
By their numbers in this assay, from the lowest: compounds 2, 4 and 3 (each within the scatter of the next); then compound 1.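

Among these compounds, removing the hydroxymethyl from the saturated chain carbon bound to an amide-type nitrogen and a carbonyl carbon gives a 1.2-fold higher number from compound 2 to compound 4 (0.06 log units; within the scatter) in this assay, which is the first direct reading of this change. In this pair, the hydroxymethyl can give way to hydrogen without a step beyond the scatter, so the group makes no visible difference to this read-out when the rest of compound 2 stays the same. The earlier step, a 5.8-fold lower number from compound 1 to compound 2 (0.76 log units; beyond the scatter), changed a group elsewhere and remains the only step shown that lies beyond the scatter, while no available measurement explains why the present change leaves the number within the scatter.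

Going by these compounds, only hydrogen and hydroxymethyl have been compared on this carbon, so it remains open how a methyl, a carboxylic acid or an aminomethyl group there would read in this assay. On these data alone, it also remains open whether losing the hydroxymethyl would stay within the scatter in compound 1, which carries a different chain, since a single pair cannot show whether this result holds beyond compound 2 and compound 4.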